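A few compounds are considered here, and "the series" means these few. Any claim that something is new, unique, unknown or untested is made for them only; others in the source may bear on it.

Of the compounds shown here, three sharing one core have been measured in a functional assay on HeLa cells (Homo sapiens) for antiproliferative activity, read by MTT assay, with a stated time of 72 h; a lower number here means a stronger inhibitor, a higher number a weaker inhibitor. Compound 1 `COc1cc(C(=O)c2sc3ccccc3c2-c2ccc(F)cc2)cc(OC)c1OC`, which carries a 4-fluorophenyl group, gives 3000 nM. Compound 2 `COc1cc(C(=O)c2sc3ccccc3c2-c2ccc(SC)cc2)cc(OC)c1OC`, which carries a 4-(methylsulfanyl)phenyl group instead, gives 3500 nM. Compound 3 `COc1ccc(-c2c(C(=O)c3cc(OC)c(OC)c(OC)c3)sc3ccccc23)c(OC)c1`, with a 2,4-dimethoxyphenyl group, gives 3900 nM. That value stands within the scatter of the other two, as the data show a 1.3-fold higher number from compound 1 to compound 3 (0.11 log units; within the scatter) and a 1.1-fold higher number from compound 2 to compound 3 (0.05 log units; within the scatter).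

Compound 4 `COc1ccc(OC)c(-c2c(C(=O)c3cc(OC)c(OC)c(OC)c3)sc3ccccc23)c1` has the same atoms as compound 3, joined differently: 2,5-dimethoxyphenyl in place of 2,4-dimethoxyphenyl on an aromatic carbon. Going by the values given here, no measured step exchanges one dimethoxyphenyl group for the other, so the evidence is indirect. It comes from the three steps that replace the aryl group on this same aromatic carbon. Besides the two above, these include a 1.2-fold higher number from compound 1 to compound 2 (0.07 log units; within the scatter), and all three remain within the scatter. Even the replacement of a 4-fluorophenyl group by a 2,4-dimethoxyphenyl group left the number essentially in place, so no step beyond the scatter is expected in this assay, and no direction can be favoured. The expected change is a 1.1-fold lower number from compound 3 to compound 4 (0.05 log units; within the scatter). Compound 4 is estimated at 3500 nM, within an expected range of 1500 nM to 8000 nM.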

Compound 4, half-maximal inhibitory concentration: 10000 nM
Compound 4: the middle estimate sits 2.9-fold (0.46 log units) below what was measured; the measured number lies above the stated range.
By their numbers in this assay, from the lowest: compounds 1, 2 and 3 (each within the scatter of the next); then compound 4.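

Up to this point, every replacement of the aryl group on this aromatic carbon had stayed within the scatter in this assay, and the position seemed to tolerate whatever it carried, but 2,5-dimethoxyphenyl in place of 2,4-dimethoxyphenyl gives a 2.6-fold higher number from compound 3 to compound 4 (0.41 log units; beyond the scatter), a modest step beyond the scatter made with the same atoms joined differently. The 2,5-dimethoxyphenyl group also stands apart from the other two aryl groups, with a 2.9-fold higher number from compound 2 to compound 4 (0.46 log units; beyond the scatter) and a 3.3-fold higher number from compound 1 to compound 4 (0.52 log units; beyond the scatter), so the position does distinguish between aryl groups, and what matters here is not simply whether two methoxy groups are present, since compound 3 remains within the scatter of compound 1 and compound 2. No measurement at hand accounts for this shift.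

The compounds shown leave open whether a phenyl group with a single methoxy group, or a phenyl group with two ethoxy or two hydroxyl groups in place of the methoxy groups of the 2,5-dimethoxyphenyl group, would share the higher number of compound 4. They also leave open how an amine or a carboxylic acid on this phenyl ring would move the number, and in which direction.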